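The source may report more compounds than this note shows. Statements on the series, on what has been measured and on what is new or still open speak of the compounds shown alone.

Measured compounds in a functional assay on LNCaP cells (Homo sapiens) for antiproliferative activity, read by fluorescence and propidium iodide staining, with a stated time of 96 h; on this read-out higher numbers stand for weaker inhibition and lower numbers for stronger inhibition:
compound 1 `CC(O)(CSc1cccc(C(F)(F)F)c1)C(=O)Nc1cc(C(F)(F)F)cc(C(F)(F)F)c1`: 8750 nM
compound 2 `CC(O)(CSc1ccccc1C(F)(F)F)C(=O)Nc1cc(C(F)(F)F)cc(C(F)(F)F)c1`: 3570 nM
compound 3 `CC(O)(CS(=O)(=O)c1cccc(C(F)(F)F)c1)C(=O)Nc1cc(C(F)(F)F)cc(C(F)(F)F)c1`: 9500 nM

Compound 4 `CC(O)(CS(=O)(=O)c1ccccc1C(F)(F)F)C(=O)Nc1cc(C(F)(F)F)cc(C(F)(F)F)c1` has not yet been measured in this assay. The three measured compounds share a hydroxy amide bearing a bis(trifluoromethyl)phenyl group; compound 3 carries a sulfonyl where compound 1 carries a plain sulfur, and the difference between these two cores is not broken down here. The values of compound 1 and compound 3 lie within the scatter of each other.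

Within the sulfur series, 2-(trifluoromethyl)phenyl in place of 3-(trifluoromethyl)phenyl on a sulfur gave a 2.5-fold lower number from compound 1 to compound 2 (0.39 log units; beyond the scatter). Compound 4 arises from compound 3 by 2-(trifluoromethyl)phenyl in place of 3-(trifluoromethyl)phenyl on a sulfonyl sulfur. The place differs: in compound 1 the change is on a sulfur whose other neighbours are a saturated chain carbon, in compound 3 on a sulfonyl sulfur whose other neighbours are a saturated chain carbon, so this is the same kind of change, not the same change.

The expectation for compound 4 rests on a 2.5-fold lower number from compound 1 to compound 2 (0.39 log units; beyond the scatter), with extra uncertainty from the different place. Its starting point is the value of compound 3, 9500 nM. The expected step is a 2.1-fold lower number from compound 3 to compound 4 (0.32 log units; beyond the scatter). Compound 4 is estimated at 4500 nM, between 2000 nM and 10000 nM.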

Compound 4, half-maximal inhibitory concentration: 8510 nM
Compound 4: the middle estimate sits 1.9-fold (0.28 log units) below what was measured; the range from low to high includes it.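

In this assay, going by these compounds alone, 2-(trifluoromethyl)phenyl in place of 3-(trifluoromethyl)phenyl on a sulfonyl sulfur gave a 1.1-fold lower number from compound 3 to compound 4 (0.05 log units; within the scatter), so on this core the swap produced no step that stands out from the usual scatter. Set beside the same swap on the plain sulfur core, the two results cannot be told apart: the same change on two cores in this assay, a 2.5-fold lower number (0.39 log units; beyond the scatter) from compound 1 to compound 2 and a 1.1-fold lower number (0.05 log units; within the scatter) from compound 3 to compound 4, 2.2-fold (0.34 log units) apart, within the scatter of two such steps. Within the data shown here, this shows neither that the change carries from one core to the other nor that it fails to, since a single pair on each core fits both a shared effect and one seen only on the plain sulfur core.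

The compounds shown leave open how the same swap behaves on a core with a sulfoxide, where the sulfur carries one oxygen instead of none or two. They also leave open whether a different group on the phenyl ring, such as a nitrile or a chlorine in place of trifluoromethyl, would give a clearer step on either core.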